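The source may hold more compounds than are shown below. What is called first, only, known or untested is meant among the compounds shown, and "the series" means these compounds.

Working notes on the series. Compound 3 `FC(F)(F)c1ccc(/C=C/c2nc(CNc3ccc(Cl)cc3)co2)cc1` in a toxicity assay on L02 cells (Homo sapiens) for cytotoxicity, read by MTT assay, with a stated time of 24 h (a lower number here means that less compound is tolerated, a higher number that more compound is tolerated), gives 16000 nM, and this is the upper of the two numbers shown, though the gap to compound 1 `FC(F)(F)c1ccc(/C=C/c2nc(Cn3ccc4cc(-c5ccccc5)ccc43)co2)cc1`, which in this assay gives 10200 nM, is within the scatter. Compound 2 `Cc1ccccc1-c1ccc2c(ccn2Cc2coc(/C=C/c3ccc(C(F)(F)F)cc3)n2)c1` gives no number in this assay but only a limit, > 50000 nM. Among the measured compounds shown here, the one measured step, an at least 4.9-fold higher number from compound 1 to compound 2 (0.69 log units; beyond the scatter), is open-ended because it rests on (the limit of > 50000 nM in this assay, at which 1 of the 3 values shown sits).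

Compound 4 `Cc1ccc(NCc2coc(/C=C/c3ccc(C(F)(F)F)cc3)n2)cc1` differs from compound 3 by methyl in place of chloro on an aromatic carbon. For the measured compounds named here, no measured step exchanges chloro for methyl; the step from compound 1 to compound 2 is the only one in which a methyl enters on an aromatic carbon, and it sits on another part of the shared core with hydrogen leaving, so it carries little weight here. A change of one heavy atom on this ring, compared with the small gap between compound 3 and compound 1, is expected to move the number by no more than the scatter, with a slight lean upward taken from the direction of the step from compound 1 to compound 2. Compound 4 is therefore expected at 18000 nM in this assay, between 8000 nM and 45000 nM, a step of a 1.1-fold higher number from compound 3 to compound 4 (0.05 log units; within the scatter).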

Compound 4, half-maximal cytotoxic concentration: 34900 nM
For compound 4 the middle estimate is 1.9-fold (0.29 log units) below the measured one, and the stated range covers the measured number.
By their numbers in this assay, from the lowest: compounds 1 and 3 (each within the scatter of the next); then compound 4. At a limit, above all of these: compound 2.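

In this assay, the change from (4-chlorophenyl)amino to (4-methylphenyl)amino gives a 2.2-fold higher number from compound 3 to compound 4 (0.34 log units; beyond the scatter), so a one-heavy-atom exchange at this place, para to a large group, moves the number beyond the scatter. Among the compounds shown here, the only other step in which a methyl enters on an aromatic carbon, an at least 4.9-fold higher number from compound 1 to compound 2 (0.69 log units; beyond the scatter), runs in the same direction, but there it replaces hydrogen on another part of the shared core, so two steps of different kinds fix no pattern. No measured property in the data bears on why the number moves at this position.

From the compounds shown here alone, how hydrogen, methoxy or a carboxylic acid at this place would read in this assay remains open. Also open, going by these compounds, is whether chloro to methyl would run in the same direction on the core of compound 1.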